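The source may hold more compounds than are shown below. What is called first, only, known or untested is meant among the compounds shown, and "the series" means these compounds.

Measured compounds:
compound 1, `Cc1cccc(Cl)c1NC(=O)CN1CCN(c2nnc(Cc3ccncc3)c3ccccc23)CC1`, giving 22600 nM in a functional assay on HT-29 cells (Homo sapiens) for cytotoxicity, read by MTT assay, with a stated time of 72 h; on this read-out lower numbers stand for stronger inhibition and higher numbers for weaker inhibition
compound 2, `O=C(CN1CCN(c2nnc(Cc3ccccc3)c3ccccc23)CC1)Nc1ccc(F)c(C(F)(F)F)c1`, giving 4590 nM in this assay
compound 3, `O=C(CN1CCN(c2nnc(Cc3ccccc3)c3ccccc23)CC1)Nc1cccc(Br)c1`, giving 13400 nM in this assay

Three compounds share a core and differ in the aryl group on the amide-type nitrogen and in the pendant ring of the benzylic arm. Compound 1 gives the highest number among the three in this assay; the gap to compound 2 lies beyond the scatter, while the gap to compound 3 lies within it, so compound 1 and compound 3 cannot be told apart on these data.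

Compound 4, `Cc1ccccc1NC(=O)CN1CCN(c2nnc(Cc3ccncc3)c3ccccc23)CC1`, is the unmeasured partner of compound 1. The change is hydrogen in place of chloro on an aromatic carbon. Within the data shown here, only one measured step bears on it: a 2.9-fold higher number from compound 2 to compound 3 (0.47 log units; beyond the scatter), also a change on the aryl group of the amide-type nitrogen, and modest in size. Among the measured compounds shown here, no measured pair shows the loss of a chloro alone, so the direction of the step is uncertain. Compound 4 is therefore expected to stay close to compound 1, with a step of a 1.2-fold higher number from compound 1 to compound 4 (0.06 log units; within the scatter) that is estimated to lie near the scatter. The estimate for compound 4 in this assay is 26000 nM, with a range from 10000 nM to 65000 nM.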

Compound 4, half-maximal inhibitory concentration: 15000 nM
Compound 4: middle estimate off by 1.7-fold (0.24 log units), on the high side; the measured number falls inside the stated range.
By their numbers in this assay, from the lowest: compound 2; then compounds 3, 4 and 1 (each within the scatter of the next).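

In this assay the change from 2-chloro-6-methylphenyl to 2-methylphenyl gives a 1.5-fold lower number from compound 1 to compound 4 (0.18 log units; within the scatter) and so leaves the number within the scatter, which means that compound 1 and compound 4 cannot be told apart. Among these compounds, this is the first pair to isolate one substituent on this aromatic carbon, ortho to a large group, and it shows that chloro and hydrogen at this position are not separated by this read-out, whereas the earlier change on the aryl group of the amide-type nitrogen, a 2.9-fold higher number from compound 2 to compound 3 (0.47 log units; beyond the scatter) and beyond the scatter, replaced a different substitution pattern and could not speak to this position alone. No measurement at hand offers an explanation for this result.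

The compounds shown leave open whether an amine or a carboxylic acid on this aromatic carbon would move the number beyond the scatter, and whether losing the methyl group of the 2-methylphenyl ring would do so. From the compounds shown here alone, it also remains open whether hydrogen in place of chloro would give a similarly small step on the compounds whose benzylic arm carries the pendant ring of compound 2 and compound 3.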